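Indazole removed, dimethylcarbamoyl pyrazole returned

The source may hold more compounds than are shown below. What is called first, only, known or untested is meant among the compounds shown, and "the series" means these compounds.

Of the compounds shown here, three built on one shared core have been tested in a functional assay on cells for antagonist activity at Glucagon receptor (Homo sapiens), read by cAMP accumulation, in the presence of a further agent that is not named here; a lower number here means a stronger inhibitor, a higher number a weaker inhibitor. Compound 1 `CCCC(Oc1ccc(-n2cc(OC)cn2)cc1)c1ccc(C(=O)NCCC(=O)O)cc1` reaches only > 23000 nM, which is a limit of the assay and not a number (the limit of > 23000 nM in this assay, at which 1 of the 3 values shown sits). Compound 2 `CCCC(Nc1ccc(-n2cc(C(F)(F)F)cn2)nc1)c1ccc(C(=O)NCCC(=O)O)cc1` gives 1300 nM in this assay. Compound 3 `CCCC(Oc1ccc(-n2cc3ccccc3n2)cc1)c1ccc(C(=O)NCCC(=O)O)cc1` gives 2000 nM. Going by the values given here, only one pair differs in a single place, and that step, an at least 11-fold lower number from compound 1 to compound 3 (1.06 log units; beyond the scatter), is a large one. Among the numbers shown, compound 3 holds the highest, but compound 2 sits within the scatter of it, so no order between compound 2 and compound 3 can be read.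

Compound 4 `CCCC(Oc1ccc(-n2cc(C(=O)N(C)C)cn2)cc1)c1ccc(C(=O)NCCC(=O)O)cc1` has not been measured. It differs from compound 3 by 4-(dimethylcarbamoyl)-1H-pyrazol-1-yl in place of 2H-indazol-2-yl on an aromatic carbon. The step that bears on this change is an at least 11-fold lower number from compound 1 to compound 3 (1.06 log units; beyond the scatter), where a substituted pyrazol-1-yl on that aromatic carbon gave way to the 2H-indazol-2-yl and the number fell by at least that much. Compound 4 puts a pyrazol-1-yl back on that carbon, now carrying a dimethylcarbamoyl group, so a step back toward a higher number is expected, of about a 5.0-fold higher number from compound 3 to compound 4 (0.70 log units; beyond the scatter). Compound 4 is estimated at 10000 nM, expected between 3000 nM and 30000 nM.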

Compound 4, antagonist equilibrium constant: > 30000 nM
Compound 4: only a limit was reported; the forecaster's own chance of this, stated with the estimate: 30%; at least 3.0-fold (0.47 log units) between middle value and limit.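

In this assay, putting 4-(dimethylcarbamoyl)-1H-pyrazol-1-yl in place of 2H-indazol-2-yl on this aromatic carbon, para to a large group, brought an at least 15-fold higher number from compound 3 to compound 4 (1.17 log units; beyond the scatter). A second substituted pyrazol-1-yl, with a carbonyl group in place of the methoxy, thus also falls well short of the 2H-indazol-2-yl, so the earlier loss with methoxy on the pyrazol-1-yl was not confined to that one group. The value of compound 4 is a limit of the assay and not a number, and the step from compound 1, which also stands at a limit, cannot be read, so the methoxy and dimethylcarbamoyl groups cannot be placed in any order: the limit of > 30000 nM in this assay, at which 1 of the 4 values shown sits.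

The compounds shown leave open how far above its limit compound 4 lies, and whether any pyrazol-1-yl on this carbon can come close to compound 3. A pyrazol-1-yl carrying a nitrile, a chlorine or a short alkyl chain in place of the dimethylcarbamoyl group would test this on the same core, as would a 2H-indazol-2-yl carrying a fluorine.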